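Benzyl to 1-methyl-1-phenylethyl on the amine nitrogen

This account rests on a few compounds, and the source may have more. Where it says the series, first, only, none or still open, it means among the compounds named here.

In a functional assay on SK-BR-3 cells (Homo sapiens) for antiproliferative activity (a higher number here means a weaker inhibitor, a lower number a stronger inhibitor), compound 1 `CC(C)=CCc1cc(C(=O)Nc2cc3ccc(OCCCNc4ccccc4)c(C)c3oc2=O)ccc1O` gives > 50000 nM, which is a limit of the assay and not a number. Among the compounds with values here, compound 2 `CC(C)=CCc1cc(C(=O)Nc2cc3ccc(OCCCNCc4ccccc4)c(C)c3oc2=O)ccc1O` gives 470 nM, the only actual number so far. Within the data shown here, the sole measured step, an at least 100-fold lower number from compound 1 to compound 2 (2.02 log units; beyond the scatter), put benzyl in place of phenyl on an amine nitrogen, so this one group has already mattered greatly. Compound 3 `CC(C)=CCc1cc(C(=O)Nc2cc3ccc(OCCCNC(C)(C)c4ccccc4)c(C)c3oc2=O)ccc1O` carries 1-methyl-1-phenylethyl in place of benzyl at that nitrogen: 1-methyl-1-phenylethyl in place of benzyl on an amine nitrogen. A smaller change than that large step is expected, leaning towards weaker activity: a 1.9-fold higher number from compound 2 to compound 3 (0.28 log units; within the scatter). For compound 3 the estimated value is 900 nM, with an expected range of 200 nM to 5000 nM.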

Compound 3, half-maximal inhibitory concentration: 960 nM
Compound 3: middle estimate off by 1.1-fold (0.03 log units), on the low side; low and high end bracket the measured number.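

With 1-methyl-1-phenylethyl on the amine nitrogen, this assay shows only a 2.0-fold higher number from compound 2 to compound 3 (0.31 log units; beyond the scatter), so the large gain over phenyl is not confined to benzyl. The change from phenyl remains large, an at least 52-fold lower number from compound 1 to compound 3 (1.71 log units; beyond the scatter). Compound 1 has a limit of the assay and not a number, so that step is only a bound: the limit of > 50000 nM in this assay, at which 1 of the 3 values shown sits.

Still open, going by these compounds, is whether a single methyl on the benzyl carbon, or a longer chain leading to the phenyl ring, would keep this activity. A tertiary amine at this nitrogen is also untested here.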